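This account rests on a few compounds, and the source may have more. Where it says the series, first, only, none or still open, it means among the compounds named here.

Measured in a functional assay on thoracic aorta for inhibition of Voltage-gated L-type calcium channel (Rattus norvegicus); a lower number here means a stronger inhibitor, a higher number a weaker inhibitor:
compound 1, `CC1=NC(C)=C(C(=O)O)C(c2ccccc2[N+](=O)[O-])/C1=C(\O)OC/C=C/c1ccccc1`, 31 nM
compound 2, `CC1=NC(C)=C(C(=O)O)C(c2cccc(Cl)c2)/C1=C(\O)OC/C=C/c1ccccc1`, 20 nM
compound 3, `CC1=NC(C)=C(C(=O)O)C(c2cccc(I)c2)/C1=C(\O)OC/C=C/c1ccccc1`, 13 nM

Compound 3 is separated from compound 1 by a modest step, a 2.4-fold lower number from compound 1 to compound 3 (0.38 log units; beyond the scatter); the step of a 1.5-fold lower number from compound 2 to compound 3 (0.19 log units; within the scatter) is within the scatter, as is a 1.6-fold lower number from compound 1 to compound 2 (0.19 log units; within the scatter). Compound 4, `CC1=NC(C)=C(C(=O)O)C(c2ccoc2)/C1=C(\O)OC/C=C/c1ccccc1`, differs from compound 3 in one place: furan-3-yl in place of 3-iodophenyl on a saturated ring carbon. The three measured steps all change the group on this same saturated ring carbon, and all were small, but none of them swaps the six-membered aromatic ring for a five-membered one, so they bear only loosely on this change. A step toward a higher number in this assay is therefore expected, of about a 3.1-fold higher number from compound 3 to compound 4 (0.49 log units; beyond the scatter), with wide uncertainty. Compound 4 is estimated at 40 nM, in the range 12 nM to 130 nM.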

Compound 4, half-maximal inhibitory concentration: 130 nM
Compound 4: the middle estimate sits 3.3-fold (0.51 log units) below what was measured; measured number inside the range.
By their numbers in this assay, from the lowest: compounds 3, 2 and 1 (each within the scatter of the next, the first and the last beyond it); then compound 4.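

In this assay, going by these compounds alone, a five-membered ring on this saturated ring carbon costs far more than the earlier swaps among six-membered aromatic groups: furan-3-yl in place of 3-iodophenyl gives a 10-fold higher number from compound 3 to compound 4 (1.00 log units; beyond the scatter) as the largest step so far. The steps of a 6.5-fold higher number from compound 2 to compound 4 (0.81 log units; beyond the scatter) and a 4.2-fold higher number from compound 1 to compound 4 (0.62 log units; beyond the scatter) run the same way, both beyond the scatter. All three substituted phenyl groups therefore give lower numbers than furan-3-yl.

No measurement shown gives a reason for this difference. Ring size and the ring oxygen change together here, and an unsubstituted phenyl, a thiophene or a pyridine on this carbon would be needed to separate them.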